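The source may report more compounds than this note shows. Statements on the series, on what has been measured and on what is new or still open speak of the compounds shown alone.

Measured compounds in a functional assay on cells for positive allosteric modulation of metabotropic glutamate receptor 5 (Rattus norvegicus), read by calcium flux; on this read-out higher numbers stand for an effect only at larger amounts of compound and lower numbers for an effect already at smaller amounts:

compound 1, `O=C(Nc1cc(-c2ccccc2)nn1-c1ccccc1)c1ccccc1`: 203 nM
compound 2, `O=C(Nc1cc(-c2ccccc2)nn1-c1ccccc1)c1cccc([N+](=O)[O-])c1`: 39 nM
compound 3, `O=C(Nc1cc(-c2ccccc2)nn1-c1ccccc1Br)c1ccccc1`: 200 nM

Compound 1 and compound 2 share one core and differ by nitro in place of hydrogen on an aromatic carbon. That change gives a 5.2-fold lower number from compound 1 to compound 2 (0.72 log units; beyond the scatter). Compound 1 and compound 3 differ by bromo in place of hydrogen on an aromatic carbon, and this gives a 1.0-fold lower number from compound 1 to compound 3 (0.01 log units; within the scatter), so on the core of compound 3 nothing is seen in this assay that sets it apart from the core of compound 1.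

Compound 4, `O=C(Nc1cc(-c2ccccc2)nn1-c1ccccc1Br)c1ccc([N+](=O)[O-])cc1`, is not yet measured. It differs from compound 3 by nitro in place of hydrogen on an aromatic carbon. Among the measured compounds shown here, this is the same kind of change as the one from compound 1 to compound 2, but not the same: there the nitro sits meta to a large group, here it sits para to a large group. For the measured compounds named here, whether the para placing behaves like the meta placing cannot be read from the three measured compounds, which hold no para-substituted example.

For compound 4 a step of a 4.0-fold lower number from compound 3 to compound 4 (0.60 log units; beyond the scatter) is expected, resting on the step of a 5.2-fold lower number from compound 1 to compound 2 (0.72 log units; beyond the scatter) and on the unchanged number seen in a 1.0-fold lower number from compound 1 to compound 3 (0.01 log units; within the scatter), with wider uncertainty due to the different place of the nitro. The value of compound 4 in this assay is thus estimated at 50 nM, with a likely range from 18 nM to 160 nM.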

Compound 4, half-maximal effective concentration: 61 nM
Estimate against measurement, compound 4: 1.2-fold (0.09 log units) below; the range from low to high includes it.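

In this assay, nitro in place of hydrogen on an aromatic carbon gives a 3.3-fold lower number from compound 3 to compound 4 (0.52 log units; beyond the scatter), on a core that carries the bromo. Set beside the earlier step, this gives no sign that the bromo alters what the change does, as the two steps do not differ beyond the scatter: the same change on two cores in this assay, a 5.2-fold lower number (0.72 log units; beyond the scatter) from compound 1 to compound 2 and a 3.3-fold lower number (0.52 log units; beyond the scatter) from compound 3 to compound 4, 1.6-fold (0.20 log units) apart, within the scatter of two such steps This shows that a lower number with nitro in place of hydrogen is seen on both cores, but it does not show that the place of the nitro is without effect: the two steps differ in the core and in the place of the nitro at once, with the nitro para to a large group only in the newer step, and two cores give no rule for the whole series.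

Open, from the compounds shown here alone, is whether a nitro para to a large group on the core of compound 1 would give a step of the same size, which would separate the effect of the place from that of the core. Also open, going by these compounds, is whether the lower number belongs to nitro alone or would appear with a nitrile, an amine or a carboxylic acid on the same aromatic carbon.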